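Hydroxy on the ethoxy chain of the biaryl series

The compounds below may be only part of what the source reports. "The series", "measured", "known", "first", "only" and "open" are said of these compounds alone.

Among the compounds with values here, compound 2 `CCOc1ccc(-c2cccc(CNc3ccc(OCC(=O)O)c(F)c3)c2)c(C)c1` gives 11.6 nM in a functional assay on CHO cells for agonist activity at Free fatty acid receptor 1 (Homo sapiens), read by FLIPR and calcium flux (a higher number here means that more compound is needed for the effect, a lower number that less compound is needed), the lowest of the two numbers measured so far. Compound 1 `CC(C)c1ccccc1-c1cccc(CNc2ccc(OCC(=O)O)c(F)c2)c1` gives 86.2 nM in this assay, and the step is a 7.4-fold lower number from compound 1 to compound 2 (0.87 log units; beyond the scatter). Compound 3 `Cc1cc(OCCO)ccc1-c1cccc(CNc2ccc(OCC(=O)O)c(F)c2)c1` differs from compound 2 by hydroxy in place of hydrogen on a saturated chain carbon, two bonds along the chain from an oxygen on an aromatic ring, which read one bond further out is ethoxy to 2-hydroxyethoxy. Within the data shown here, the only measured step exchanges the whole aryl group on the shared core and touches no chain of this kind, so nothing measured bears directly on the change. Without such a precedent, no step beyond the scatter is expected in this assay, with at most a lean toward a somewhat higher number. For compound 3 the expected step is a 1.4-fold higher number from compound 2 to compound 3 (0.14 log units; within the scatter). Compound 3 is therefore estimated to give about 16 nM in this assay, with a range from 6 nM to 45 nM.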

Compound 3, half-maximal effective concentration: 36.1 nM
Estimate against measurement, compound 3: 2.3-fold (0.35 log units) below; low and high end bracket the measured number.
By their numbers in this assay, from the lowest: compound 2; then compound 3; then compound 1.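

Within the data shown here, with the first measured change on the chain itself, hydroxy in place of hydrogen on a saturated chain carbon, two bonds along the chain from an oxygen on an aromatic ring, gives a 3.1-fold higher number from compound 2 to compound 3 (0.49 log units; beyond the scatter) in this assay. Among these compounds, the outer end of the ethoxy group is therefore not indifferent to substitution: ethoxy to 2-hydroxyethoxy moves the number beyond the scatter, whereas the only earlier step exchanged the whole aryl group. No measurement at hand gives a reason for this step.

From the compounds shown here alone, whether the rise belongs to the hydroxy itself remains open, and a methoxy, an amine or a carboxylic acid at the same chain end would test this. Also open, going by these compounds, is whether a longer chain carrying the hydroxy would give a lower or higher number than compound 3.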